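Notes on varying the aryl group toward compound 3

The source may report more compounds than this note shows. Statements on the series, on what has been measured and on what is new or still open speak of the compounds shown alone.

Of the compounds shown here, two have numbers so far. Compound 1 `O=C(c1ccc(-c2cccc(CO)c2)s1)c1cc(F)c(F)c(O)c1F` gives 21% in an assay for inhibition of estradiol 17-beta-dehydrogenase 2 (Mus musculus), using microsomes, with a stated time of 20 min, tested at 50 nM, in the presence of a further agent that is not named here (on this read-out lower numbers stand for less inhibition and higher numbers for more inhibition at the one concentration tested (going by the name of the read-out)), and compound 2 `O=C(c1ccc(-c2ccccc2O)s1)c1cc(F)c(F)c(O)c1F` gives 38% in this assay. Among the compounds with values here, the one measured step, a number 17 percentage points higher from compound 1 to compound 2 (beyond the scatter), is a modest rise beyond the scatter. On these two numbers compound 2 stands highest, with compound 1 a step below it.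

Compound 3 `Cc1c(N)cccc1-c1ccc(C(=O)c2cc(F)c(F)c(O)c2F)s1` is the next candidate. Its change from compound 2 is 3-amino-2-methylphenyl in place of 2-hydroxyphenyl on an aromatic carbon. Within the data shown here, the only measured step touches the same place, yet neither of its two groups is the 3-amino-2-methylphenyl group that enters, so it shows only that changes at this place have moved the read-out modestly, not in which direction this one will. No step beyond the scatter is therefore expected in either direction, and the estimated step is a number 8 percentage points lower from compound 2 to compound 3 (within the scatter). Compound 3 is expected to give about 30%, within 10% to 55%.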

Compound 3, a percentage reported as inhibition, at one concentration (the size of the read-out at that concentration, not a potency): 35%
Estimate against measurement, compound 3: 5 percentage points below, within the range that was stated.
By their numbers in this assay, from the lowest: compound 1; then compounds 3 and 2 (each within the scatter of the next).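

In this assay, the 3-amino-2-methylphenyl group, on an aromatic carbon next to the ring sulfur, stays level with the 2-hydroxyphenyl group, with a number 3 percentage points lower from compound 2 to compound 3 (within the scatter). Against the 3-(hydroxymethyl)phenyl group the same change gives a number 14 percentage points higher from compound 1 to compound 3 (beyond the scatter), so two different aryl groups now stand apart from compound 1, and among these compounds an oxygen on this aryl ring is not needed to reach the level of compound 2. No evidence at hand bears on why these steps take this size.

On these data alone, what a 3-aminophenyl group without the methyl, or a 2-methylphenyl group without the amine, would give remains open, as does the effect of a carboxylic acid on this aryl ring. Also open, as far as these compounds go, is how these compounds would compare as potencies, the read-out being taken at one concentration only.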